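Fluoro to methyl: transferring one step to a second core

A few compounds are considered here, and "the series" means these few. Any claim that something is new, unique, unknown or untested is made for them only; others in the source may bear on it.

Compound 1 `O=[N+]([O-])c1cccc(S(=O)(=O)Nc2ccc(F)cc2)c1` gives 7.27 in a physicochemical assay for acid dissociation. Compound 2 `Cc1ccc(NS(=O)(=O)c2cccc([N+](=O)[O-])c2)cc1` differs from it by methyl in place of fluoro on an aromatic carbon, and in this assay compound 2 gives 7.8; the change produced a number 0.53 log units higher from compound 1 to compound 2 (beyond the scatter). Compound 3 `O=[N+]([O-])c1ccc(S(=O)(=O)Nc2ccc(F)cc2)cc1` is built on a different core; the difference between the two cores is not broken down here. In this assay compound 3 gives 6.45, the lowest of the three numbers, with the gaps to compound 1 and to compound 2 both beyond the scatter. Compound 4 `Cc1ccc(NS(=O)(=O)c2ccc([N+](=O)[O-])cc2)cc1` is the unmeasured partner of compound 3 and differs from it by methyl in place of fluoro on an aromatic carbon, the same change as between compound 1 and compound 2, at a place described in identical words. Among the measured compounds shown here, only a single measured instance of this change exists. The step from compound 3 to compound 4 is expected to be a number 0.53 log units higher from compound 3 to compound 4 (beyond the scatter). For the measured compounds named here, this expectation rests on the one measured step, a number 0.53 log units higher from compound 1 to compound 2 (beyond the scatter), with the range held somewhat wider than that step alone because only compound 1 and compound 2 support it. Compound 4 is therefore expected to give 6.98, within 6.6 to 7.4.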

Compound 4, acid dissociation constant: 6.78
Beside the measured number, compound 4's estimate is 0.20 log units above it; the range from low to high includes it.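

In this assay, replacing fluoro with methyl on an aromatic carbon gives a number 0.33 log units higher from compound 3 to compound 4 (beyond the scatter), and on the core of compound 1 the same change gives a number 0.53 log units higher from compound 1 to compound 2 (beyond the scatter), so the step carries over in direction between these two cores. Only these two pairs support the transfer, so they establish no rule for other cores and do not settle whether the size of the step depends on the core. No measured information is available to explain either step or how the two steps compare.

The compounds shown leave open whether another group in the same place, para to a large group, such as an amine, a carboxylic acid or a longer chain like ethyl, would follow the order seen with fluoro and methyl on both cores. They also leave open whether the fluoro to methyl step would keep its direction on a third core.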